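Methoxyphenyl in place of chlorophenyl on the shared core

A few compounds are considered here, and "the series" means these few. Any claim that something is new, unique, unknown or untested is made for them only; others in the source may bear on it.

Compound 3 `NS(=O)(=O)NCC1CCN(c2cc(-c3ccc(Cl)cc3)ncn2)CC1` gives 50300 nM in a functional assay on M21 cells (Homo sapiens) for antiproliferative activity, read by sulforhodamine B assay, with a stated time of 48 h (on this read-out lower numbers stand for stronger inhibition of growth and higher numbers for weaker inhibition of growth), the highest of the two numbers seen; its nearest neighbour is compound 2 `CCCCc1ccc(-c2cc(N3CCC(CNS(N)(=O)=O)CC3)ncn2)cc1` at 47200 nM, and a 1.1-fold higher number from compound 2 to compound 3 (0.03 log units; within the scatter). Compound 1 `NS(=O)(=O)NCC1CCN(c2cc(-c3ccccc3)ncn2)CC1` reaches only the limit of this assay, > 100000 nM. Against that limit there is an at least 2.1-fold lower number from compound 1 to compound 2 (0.32 log units; beyond the scatter) and an at least 1.9-fold lower number from compound 1 to compound 3 (0.29 log units; that floor lies within the scatter). Compound 4 `COc1ccccc1-c1cc(N2CCC(CNS(N)(=O)=O)CC2)ncn1` carries 2-methoxyphenyl in place of 4-chlorophenyl on an aromatic carbon. The measured steps all concern a group on the phenyl, but none introduces a hydrogen-bond acceptor there, so they bear on the change only loosely; each stayed close to the scatter, and the whole measured span is narrow. No step beyond the scatter is therefore expected in this assay. Compound 4 is expected at 60000 nM, within 20000 nM to 150000 nM. This amounts to an expected 1.2-fold higher number from compound 3 to compound 4 (0.08 log units; within the scatter).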

Compound 4, concentration for 50% growth inhibition: > 100000 nM
Compound 4: only a limit was reported; the forecaster's own chance of this, stated with the estimate: 30%; at least 1.6-fold (0.22 log units) between middle value and limit.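

In this assay, among these compounds, 2-methoxyphenyl in place of 4-chlorophenyl, the first phenyl group here to carry a hydrogen-bond acceptor, gives an at least 1.9-fold higher number from compound 3 to compound 4 (0.29 log units; that floor lies within the scatter), so the change brings no gain in growth inhibition. Compound 4 gives > 100000 nM, which is a limit and not a number. The step from compound 1 to compound 4 cannot be read, so methoxy and hydrogen cannot be ranked at this position: the limit of > 100000 nM in this assay, at which 2 of the 4 values shown sit.

The compounds shown leave open whether the methoxy group itself or its position on the phenyl decides this result. Also open, as far as these compounds go, is whether an amine or a carboxylic acid on the phenyl would give a readable value.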